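Amide swap on the way to compound 4

A few compounds are considered here, and "the series" means these few. Any claim that something is new, unique, unknown or untested is made for them only; others in the source may bear on it.

Measured so far in a physicochemical assay for solubility, read by chemiluminescence, measured as kinetic solubility (a lower number here means a less soluble compound, a higher number a more soluble compound), for three compounds
compound 1 `CC(=O)NCc1cccc(Cn2nc(NS(=O)(=O)c3ccc(Cl)s3)c3c(C(C)=O)cccc32)c1` gives 57 ug/mL
compound 2 `CC(=O)NCc1cccc(Cn2nc(NS(=O)(=O)c3ccc(Cl)s3)c3c(C(C)(C)O)cccc32)c1` gives >= 159 ug/mL as a limit
compound 3 `COc1cccc2c1c(NS(=O)(=O)c1ccc(Cl)s1)nn2Cc1cccc(CNC(=O)C2CCCO2)c1` gives >= 153 ug/mL as a limit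

Compound 3 stands at >= 153 ug/mL in this assay as a limit and not a number. Compound 2 likewise stands at >= 159 ug/mL as a limit. Only compound 1 has a plain number.

Compound 4 `COc1cccc2c1c(NS(=O)(=O)c1ccc(Cl)s1)nn2Cc1cccc(CNC(=O)C(C)(C)N)c1` departs from compound 3 in one place 1-amino-1-methylethyl in place of oxolan-2-yl on a carbonyl carbon with 1-amino-1-methylethyl in place of oxolan-2-yl on a carbonyl carbon. Going by the values given here, the one measured step is an at least 2.7-fold higher number from compound 1 to compound 2 (0.44 log units; beyond the scatter) and it puts 1-hydroxy-1-methylethyl in place of acetyl on an aromatic carbon. That is a different place, so it bears only loosely on this change. The expectation therefore rests mainly on compound 3 and its limit of >= 153 ug/mL in the absence of any measured step at the carbonyl carbon.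

The expected change, none beyond the scatter, is an at least 1.0-fold lower number from compound 3 to compound 4 (0.00 log units; that floor lies within the scatter) in this assay for this swap. Compound 4 is estimated at 150 ug/mL with an expected range from 85 ug/mL to 200 ug/mL and may well report only a limit.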

Compound 4, solubility: >= 180 ug/mL
Compound 4: no number, only a limit; the forecaster's own chance of this, stated with the estimate: 65%; middle value at least 1.2-fold (0.07 log units) from the limit.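

In this assay compound 3 gives >= 153 ug/mL, a limit and not a number. Going by these compounds alone, compound 4 gives >= 180 ug/mL, again a limit, so no step between compound 3 and compound 4 can be read. Going by these compounds, whether 1-amino-1-methylethyl in place of oxolan-2-yl on a carbonyl carbon changes the read-out at all stays open.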